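The compounds below may be only part of what the source reports. "The series", "measured", "known", "first", "only" and "open" are said of these compounds alone.

Measured compounds:
Compound 1, `CCOc1ccccc1-c1ccc(-c2nc3cnccc3c(N[C@H](CC)C(=O)NS(=O)(=O)C3CC3)c2C#N)cc1`: 2.3
Compound 2, `CC[C@@H](Nc1c(C#N)c(-c2ccc(-c3cccc(Cl)c3)cc2)nc2cnccc12)C(N)=O`: 3.1

In a physicochemical assay for lipophilicity, read by HPLC, at pH 7.5 (a higher number here means a more lipophilic compound, a lower number a more polar compound), compound 1 gives 2.3, the lower of the two numbers at hand. Compound 2 gives 3.1 in this assay, a gap from compound 1 that lies beyond the usual scatter. For the measured compounds named here, no pair of compounds that differ in only one place has been measured, so the effect of a single change on this assay cannot be read directly from the data.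

Compound 3, `CCOc1ccccc1-c1ccc(-c2nc3cnccc3c(N[C@@H]3CCOC3=O)c2C#N)cc1`, has not yet been measured in this assay. It differs from compound 1 in this way: a group of 6 heavy atoms (4 carbon, 2 oxygen; one five-membered non-aromatic ring with 1 hetero atom) in place of a group of 12 heavy atoms (7 carbon, 1 nitrogen, 3 oxygen, 1 sulfur; one three-membered non-aromatic ring of carbon only), on a nitrogen on an aromatic ring. The group that enters is smaller and carries no hydrogen-bond donor, as counted above, while the shared core and the ethoxy-bearing ring are kept.

Compound 3 is expected to give a higher number in this assay than compound 1, and the step from compound 1 is estimated at a number 1.40 log units higher from compound 1 to compound 3 (beyond the scatter), beyond the scatter. The estimate for compound 3 is therefore 3.7, with a range from 3.1 to 4.3.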

Compound 3, distribution coefficient: 2.7
For compound 3 the middle estimate is 1.00 log units above the measured one; the whole stated range lies above it.
By their numbers in this assay, from the lowest: compound 1; then compound 3; then compound 2.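

In this assay, exchanging the group of 12 heavy atoms with its three-membered carbon ring for 2-oxooxolan-3-yl, on a nitrogen on an aromatic ring, gives a number 0.40 log units higher from compound 1 to compound 3 (beyond the scatter), a modest step. For the compounds shown here, this is the first pair that differs in one place only, so it shows directly that this position affects the reading in this assay while the shared core and the ethoxy-bearing ring stay the same. The exchange changes several counted features at once, with fewer heavy atoms, the hydrogen-bond donors going from 1 to 0, and the sulfur leaving, and nothing at hand ties the step to any one of these.

Compound 2 differs from compound 1 and compound 3 in more than one place, so it cannot show how much of this step belongs to each feature. Going by these compounds, it also remains open where a carboxylic acid or a methyl ester on this same nitrogen would fall in this assay relative to compound 1 and compound 3, and whether the step would hold on another core.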